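The compounds below may be only part of what the source reports. "The series", "measured", "known", "first", "only" and "open" are said of these compounds alone.

Both measured compounds share one core and differ only in what hangs from it. Compound 1 `OCC(CO)(CO)Nc1nnc2nncn2n1` gives in a functional assay on MCF7 cells (Homo sapiens) for inhibition, read by MTT assay, with a stated time of 72 h (on this read-out lower numbers stand for stronger inhibition and higher numbers for weaker inhibition), no number but only a limit, > 100000 nM. Going by the values given here, compound 2 `CC(=O)N1CCN(c2nnc3nncn3n2)CC1` is the one compound with a number: in this assay compound 2 gives 13900 nM. It therefore stands alone among the shown values, the other entry, that of compound 1, being (the limit of > 100000 nM in this assay, at which 1 of the 2 values shown sits). Compound 3 `CC(C)COC(=O)N1CCN(c2nnc3nncn3n2)CC1` differs from compound 2 at a single place, (isobutoxy in place of methyl on a carbonyl carbon), which read one bond further out is acetyl turned into isobutoxycarbonyl. Among the compounds with values here, no measured pair shows what this change does in this assay, so no step can be leaned on. The change is expected to shift the read-out only modestly, if at all, and most likely within the scatter. For compound 3 the value in this assay is estimated at 10000 nM, with a range from 3000 nM to 40000 nM. The step expected, a 1.4-fold lower number from compound 2 to compound 3 (0.14 log units; within the scatter), is small.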

Compound 3, half-maximal inhibitory concentration: 5390 nM
Beside the measured number, compound 3's estimate is 1.9-fold (0.27 log units) above it; measured number inside the range.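

Going by these compounds alone, the change from acetyl to isobutoxycarbonyl gives the first readable step: in this assay it produces a 2.6-fold lower number from compound 2 to compound 3 (0.41 log units; beyond the scatter), modest in size. This shows that the read-out responds to the group on this carbonyl carbon, whose other neighbour is the amide-type nitrogen in the ring, and that isobutoxy in place of methyl moves it towards stronger inhibition rather than losing it. Nothing in the data shown accounts for the size or direction of this step.

From the compounds shown here alone, this single pair does not separate the oxygen that enters from the branched chain it carries, so it remains open whether methoxy or a plain isobutyl group on the same carbonyl carbon would move the read-out in the same way. Going by these compounds, how an amine or a phenyl group at this place would read also remains open.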